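A few compounds are considered here, and "the series" means these few. Any claim that something is new, unique, unknown or untested is made for them only; others in the source may bear on it.

Of the compounds shown here, three of one series have been measured in a functional assay on A-375 cells (Homo sapiens) for cytotoxicity, read by MTT assay, with a stated time of 72 h, tested at 1 uM; on this read-out lower numbers stand for less inhibition of growth and higher numbers for more inhibition of growth at the one concentration tested. Compound 1 `Cc1ccnc(/C(N)=N/NC(=S)N2CCOCC2)c1` gives 43.2% in this assay. Compound 2 `Cc1cccc(/C(N)=N/NC(=S)N2CCSCC2)n1` gives 47.2% in this assay. Compound 3 `Cc1ccnc(/C(N)=N/NC(=S)N2CCSCC2)c1` gives 47.7% in this assay. Compound 1 and compound 3 differ in a single place: morpholin-4-yl in place of thiomorpholin-4-yl on a thiocarbonyl carbon. This change produced a number 4.5 percentage points lower from compound 3 to compound 1 (within the scatter), a step that lies within the scatter of the measurement. Compound 2 and compound 3 are built from the same atoms joined differently; the difference between their two cores is not broken down here. Their values in this assay lie within the scatter of each other, and the value of compound 2 also lies within the scatter of that of compound 1.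

Compound 4 `Cc1cccc(/C(N)=N/NC(=S)N2CCOCC2)n1` has not yet been measured. It stands to compound 2 as compound 1 stands to compound 3, through the same change: morpholin-4-yl in place of thiomorpholin-4-yl on a thiocarbonyl carbon. The surroundings of the place are described in the same words for both pairs, so this is the same change carried out on the core of compound 2. Among the four compounds it occurs twice. Because the earlier step was a number 4.5 percentage points lower from compound 3 to compound 1 (within the scatter) and sat within the scatter, the expected step from compound 2 to compound 4 is a number 4.2 percentage points lower from compound 2 to compound 4 (within the scatter), again small. Compound 4 is therefore estimated at 43% in this assay, with a likely range from 33% to 53%. Among the compounds with values here, this expectation rests only on the value of compound 2, 47.2%, and on the single earlier step; whether the swap behaves alike on the core of compound 2 remains to be seen.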

Compound 4, percent growth inhibition at one concentration: 30.2%
Estimate against measurement, compound 4: 12.8 percentage points above; the measured number lies below the stated range.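

In this assay, morpholin-4-yl in place of thiomorpholin-4-yl on the thiocarbonyl carbon gives a number 17 percentage points lower from compound 2 to compound 4 (beyond the scatter), so on this core the swap produces a step larger than repeated measurements alone would account for. Set beside the step on the other core, this result does not separate from it, since the gap between the two stays within what two such steps can scatter: the same change on two cores in this assay, a number 4.5 percentage points lower (within the scatter) from compound 3 to compound 1 and a number 17 percentage points lower (beyond the scatter) from compound 2 to compound 4, 12.5 percentage points apart, within the scatter of two such steps. The two cores therefore give no ground for saying that the swap acts differently on one than on the other, yet two pairs, one of them with a step within the scatter, do not show that it carries over with a fixed size either.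

The compounds shown offer only thiomorpholin-4-yl and morpholin-4-yl on the thiocarbonyl carbon, on two cores built from the same atoms, and each is read at a single concentration in a single assay. On these data alone, it remains open how a piperidine, a piperazine or an open-chain dimethylamino group would fare in that place, and whether the pairs would keep their standing across a range of concentrations.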